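The source may report more compounds than this note shows. Statements on the series, on what has been measured and on what is new or still open speak of the compounds shown alone.

Of the compounds shown here, three have been measured so far in a functional assay on HEK293 cells for agonist activity at D(4) dopamine receptor (Homo sapiens), read by FLIPR; a higher number here means that more compound is needed for the effect, a lower number that less compound is needed. Compound 3 `Oc1ccc(N2CCN(Cc3nc4ccccc4[nH]3)CC2)nc1` gives 2.4 nM, compound 1 `CCc1cccc(NC(=O)CN2CCC(c3cccc[n+]3[O-])CC2)c1` gives 95 nM, and compound 2 `COc1ccccc1C1CCN(CC(=O)Nc2cccc(C)c2)CC1` gives 420 nM, the highest of the three numbers; its gaps to compound 1 and to compound 3 both lie beyond the usual scatter, so compound 2 needs the largest amount of the three for the effect. The three compounds differ from one another in several places at once, so no single change among them can be tied to a step in this assay.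

Compound 4 `Cc1cccc(NC(=O)CN2CCC(c3ccccc3C)CC2)c1` differs from compound 2 in only one place: methyl in place of methoxy on an aromatic carbon, which read one bond further out is a move from 2-methoxyphenyl to 2-methylphenyl. Going by the values given here, no measured pair shows this change, so its effect can only be estimated. A small step of a 1.4-fold lower number from compound 2 to compound 4 (0.15 log units; within the scatter) is expected, within the usual scatter. For compound 4 the expected value in this assay is 300 nM, with a range from 100 nM to 1000 nM.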

Compound 4, half-maximal effective concentration: 340 nM
For compound 4 the middle estimate is 1.1-fold (0.05 log units) below the measured one; low and high end bracket the measured number.
By their numbers in this assay, from the lowest: compound 3; then compound 1; then compounds 4 and 2 (each within the scatter of the next).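

Going by these compounds alone, this is the first pair that differs in one place only, which gives the first direct reading of a single change in this assay. Going from 2-methoxyphenyl to 2-methylphenyl gives a 1.2-fold lower number from compound 2 to compound 4 (0.09 log units; within the scatter), so at this position, on an aromatic carbon ortho to a large group, methyl and methoxy cannot be told apart in this assay, even though methoxy counts as a hydrogen-bond acceptor and methyl does not. No measurement shown here speaks to why the two groups read alike.

On these data alone, whether the same holds for quite different groups at this position, such as an amine, a carboxylic acid or a longer chain, remains open. Compounds 1 and 3 each differ from compound 4 in more than one place, so they cannot settle this question.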